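Lengthening the acid arm of a fatty-acid amide

The compounds below may be only part of what the source reports. "The series", "measured", "known", "first", "only" and "open" are said of these compounds alone.

Measured compounds, in an assay on isolated protein with Group VII phospholipase A2 (Sus scrofa) as the target; on this read-out higher numbers stand for weaker inhibition and lower numbers for stronger inhibition:
compound 1 `CCCCCCCCCCCCCCCC(=O)N[C@@H](CC(=O)O)CC(C)C`: 190 nM
compound 2 `CCCCCCCCCCCCCCCC(=O)N[C@@H](CCC(=O)O)CC(C)C`: 200 nM

Compound 2 has the highest of the two numbers, yet its neighbour compound 1 lies within the scatter of it, so the two are best read as equal. Compound 3 `CCCCCCCCCCCCCCCC(=O)N[C@@H](CCCC(=O)O)CC(C)C` continues the same kind of change: carboxymethyl in place of carboxy on a saturated chain carbon, three bonds along the chain from an amide-type nitrogen. For the measured compounds named here, the only measured step of this kind is a 1.1-fold higher number from compound 1 to compound 2 (0.02 log units; within the scatter), where adding one carbon between the chain and the acid left the number essentially unchanged. With a single step as guide, and that step within the scatter, the expectation for one more carbon is no change beyond the scatter in this assay, with a slight lean toward a higher number because a 1.1-fold higher number from compound 1 to compound 2 (0.02 log units; within the scatter) pointed weakly that way. Compound 3 is therefore estimated at 260 nM, in the range 110 nM to 650 nM, an expected step of a 1.3-fold higher number from compound 2 to compound 3 (0.11 log units; within the scatter).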

Compound 3, half-maximal inhibitory concentration: 1300 nM
Beside the measured number, compound 3's estimate is 5.0-fold (0.70 log units) below it; measured number above the stated range.
By their numbers in this assay, from the lowest: compounds 1 and 2 (each within the scatter of the next); then compound 3.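

In this assay, the length of the acid arm does matter at this position, although one step of lengthening had suggested otherwise: the next carbon gives a 6.5-fold higher number from compound 2 to compound 3 (0.81 log units; beyond the scatter), and the whole extension gives a 6.8-fold higher number from compound 1 to compound 3 (0.84 log units; beyond the scatter). The response to lengthening is therefore uneven, with compound 1 and compound 2 reading as equal and compound 3 standing apart as the weaker inhibitor. Nothing available here explains why the loss appears only at this length.

Still open, on these data alone, is whether a longer chain carrying the carboxylic acid would weaken inhibition further or whether the number would level off. As far as these compounds go, it is also open whether the acid itself is required, which a methyl ester or a primary amide at the end of the arm would test at each length.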